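A few compounds are considered here, and "the series" means these few. Any claim that something is new, unique, unknown or untested is made for them only; others in the source may bear on it.

Compound 1 `O=S(=O)(Nc1ccccc1NS(=O)(=O)c1ccc(Cl)cc1)c1ccc(F)cc1` gives 27300 nM in an assay for binding affinity to protein lin-28 homolog A (Mus musculus), with a stated time of 1 h (a lower number here means a stronger inhibitor, a higher number a weaker inhibitor), the highest number of the three in hand, though its gap to compound 3 lies within the scatter. Compound 2 `O=S(=O)(Nc1ccccc1NS(=O)(=O)c1cccc(Cl)c1)c1ccc(F)cc1` gives 10800 nM, and compound 3 `O=S(=O)(Nc1ccccc1NS(=O)(=O)c1cccc(Br)c1)c1ccc(F)cc1` gives 16200 nM. The steps of a 2.5-fold lower number from compound 1 to compound 2 (0.40 log units; beyond the scatter) and a 1.7-fold lower number from compound 1 to compound 3 (0.23 log units; within the scatter) alter the chlorophenyl on the other sulfonyl sulfur, while the step of a 1.5-fold higher number from compound 2 to compound 3 (0.18 log units; within the scatter) exchanges one halogen for another. Compound 4 `O=S(=O)(Nc1ccccc1NS(=O)(=O)c1ccc(Cl)cc1)c1ccc(Cl)cc1` differs from compound 1 by chloro in place of fluoro on an aromatic carbon. Among the measured compounds shown here, no measured step touches this ring, so only the halogen exchange between compound 2 and compound 3 bears on it, and that stayed within the scatter. A step of a 1.4-fold lower number from compound 1 to compound 4 (0.14 log units; within the scatter) is therefore expected for compound 4, not clearly beyond the scatter. The estimate for compound 4 in this assay is 20000 nM, ranging from 8000 nM to 55000 nM.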

Compound 4, half-maximal inhibitory concentration: 27500 nM
The estimate for compound 4 lay 1.4-fold (0.14 log units) below the measured number, and the stated range covers the measured number.
By their numbers in this assay, from the lowest: compounds 2, 3, 1 and 4 (each within the scatter of the next, the first and the last beyond it).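

Notes on the series: in this assay the 4-fluorophenyl to 4-chlorophenyl change, the first read at this ring, shows a 1.0-fold higher number from compound 1 to compound 4 (0.00 log units; within the scatter) and so leaves fluoro and chloro at this position indistinguishable. With 4-chlorophenyl on the other sulfonyl sulfur, this extends to a second ring what the halogen exchange between compound 2 and compound 3 suggested. No evidence bearing on the reason for this result is available.

As far as these compounds go, whether an amine or a carboxylic acid in place of the halogen here would shift the number stays open. Also open, from the compounds shown here alone, is whether the 3-chlorophenyl of compound 2 behaves alike with chloro on this ring.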